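This account rests on a few compounds, and the source may have more. Where it says the series, first, only, none or still open, it means among the compounds named here.

Compound 3 `Cc1cc(NCc2ccccn2)n2ncc(-c3ccccc3C)c2n1` carries a 2-methylphenyl on the shared core. In a physicochemical assay for solubility, read by HPLC, using the shake flask method, measured as kinetic solubility, with a stated time of 2 h, at pH 7.4 (on this read-out lower numbers stand for lower solubility and higher numbers for higher solubility), compound 3 gives < 5000 nM, which is a limit of the assay rather than a number. Compound 1 `Cc1cc(NCc2ccccn2)n2ncc(-c3ccc(F)cc3)c2n1` bears a 4-fluorophenyl in that position, and in this assay compound 1 gives < 5000 nM, also a limit. Compound 2 `COc1ccc(-c2cnn3c(NCc4ccccn4)cc(C)nc23)cc1` carries a 4-methoxyphenyl, and in this assay compound 2 gives < 5000 nM, again a limit. The steps a step that the two limits leave unreadable from compound 1 to compound 2, a step that the two limits leave unreadable from compound 1 to compound 3 and a step that the two limits leave unreadable from compound 2 to compound 3 therefore cannot be sized. Compound 4 `Cc1cc(NCc2ccccn2)n2ncc(-c3ccc(F)cc3F)c2n1` differs from compound 3 by 2,4-difluorophenyl in place of 2-methylphenyl on an aromatic carbon. Because (the limit of < 5000 nM in this assay, at which 3 of the 3 values shown sit), the expected step that the limit leaves unreadable from compound 3 to compound 4 will most likely again stay unresolved. Compound 4 is accordingly estimated at 2000 nM, with a range from 400 nM to 6000 nM.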

Compound 4, solubility: < 5000 nM
Compound 4 gave a limit, no number; the forecaster's own chance of this, stated with the estimate: 75%; the middle value does not contradict the limit.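

Within the data shown here, no step between compound 4 and compounds 1, 2 or 3 can be read, because all four give only a limit and no number: the limit of < 5000 nM in this assay, at which 4 of the 4 values shown sit. The compounds shown leave open how far their true solubilities differ, if at all, in this assay.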